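Second Chloro on the Aryl Urea: Solubility Expected to Fall

The compounds below may be only part of what the source reports. "The series", "measured", "known", "first", "only" and "open" are said of these compounds alone.

Compound 1 `Cc1cc(NC(=O)Nc2ccc(F)cc2)c2ccccc2n1`: 3700 nM
Compound 2 `Cc1cc(NC(=O)Nc2ccc(Cl)cc2)c2ccccc2n1`: 1400 nM

Within the data shown here, of the two numbers in a physicochemical assay for solubility, at pH 7.4 (on this read-out lower numbers stand for lower solubility and higher numbers for higher solubility), compound 2 stands lowest; the one measured step, a 2.6-fold lower number from compound 1 to compound 2 (0.42 log units; beyond the scatter), was modest and went down. Compound 3 `Cc1cc(NC(=O)Nc2ccc(Cl)cc2Cl)c2ccccc2n1` differs from compound 2 by chloro in place of hydrogen on an aromatic carbon. That earlier step bears on it only loosely, since a halogen is exchanged there rather than added, yet it points the same way. A modest further fall beyond the scatter is therefore expected, a 2.0-fold lower number from compound 2 to compound 3 (0.30 log units; within the scatter). Compound 3 is estimated at 700 nM, with a likely range from 300 nM to 1600 nM.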

Compound 3, solubility: 100 nM
Compound 3: the middle estimate sits 7.0-fold (0.85 log units) above what was measured; measured number below the stated range.
By their numbers in this assay, from the lowest: compound 3; then compound 2; then compound 1.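

Adding a chloro on an aromatic carbon, ortho to a large group and meta to a chloro group, gave a 14-fold lower number from compound 2 to compound 3 (1.15 log units; beyond the scatter) in this assay and so moved this read-out much further than the earlier halogen exchange had. Among these compounds, the hydrogen at this position, unchanged in the earlier compounds, thus proves to be a sensitive point for this read-out. No evidence is available to explain the size of this step. The compounds shown leave open whether a fluoro or a methyl group at this same position would lower the number as far, and what an amine there would do.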